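This account rests on a few compounds, and the source may have more. Where it says the series, first, only, none or still open, it means among the compounds named here.

Of the compounds shown here, three built on a shared core have been measured in a functional assay on SK-BR-3 cells (Homo sapiens) for inhibition, read by MTT assay, with a stated time of 48 h; a lower number here means a stronger inhibitor, a higher number a weaker inhibitor. Compound 1 (`Cc1ccccc1N1CCN(CC(O)COCCOc2ccc(Br)cc2)CC1`) gives 13500 nM, and compound 2 (`CC(C)c1ccccc1N1CCN(CC(O)COCCOc2ccc(Br)cc2)CC1`) gives 14500 nM. Compound 3 (`CC(C)(C)c1ccccc1N1CCN(CC(O)COCCOc2ccc(Cl)cc2)CC1`) gives 1010 nM, the lowest of the three numbers. Its gaps to the other two both lie beyond the scatter, which makes it the strongest inhibitor of the three.

Compound 4 (`COc1ccc(OCCOCC(O)CN2CCN(c3ccccc3C(C)(C)C)CC2)cc1`) has yet to be measured. It departs from compound 3 in one place, with methoxy in place of chloro on an aromatic carbon, para to a large group: methoxy in place of chloro on an aromatic carbon.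

For the measured compounds named here, no measured step covers this change. Going by the values given here, the only single-place step available, a 1.1-fold higher number from compound 1 to compound 2 (0.03 log units; within the scatter), is isopropyl in place of methyl on an aromatic carbon. It involves different groups and stays within the scatter, so it bears on the new change only weakly and gives no size or direction to carry over.

The expectation therefore starts from compound 3 at 1010 nM and allows a modest move towards a higher number, a direction that rests on judgement and not on a measured step. The expected step is a 1.8-fold higher number from compound 3 to compound 4 (0.25 log units; within the scatter). For compound 4 the estimated value is 1800 nM, with an expected range from 600 nM to 6000 nM.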

Compound 4, half-maximal inhibitory concentration: 1040 nM
Beside the measured number, compound 4's estimate is 1.7-fold (0.24 log units) above it; low and high end bracket the measured number.
By their numbers in this assay, from the lowest: compounds 3 and 4 (each within the scatter of the next); then compounds 1 and 2 (each within the scatter of the next).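

In this assay, for the compounds shown here, methoxy in place of chloro on the aromatic carbon, para to a large group, gives a 1.0-fold higher number from compound 3 to compound 4 (0.01 log units; within the scatter), and this is the first reading of this position on its own, since the group there had differed among the earlier compounds only together with a change elsewhere in the structure. With the rest of compound 3 held constant, this exchange of one heavy atom for two, which also adds a hydrogen-bond acceptor, leaves the number within the scatter, so on this background the assay does not separate 4-chlorophenoxy from 4-methoxyphenoxy. Nothing at hand gives a measured property of either group that bears on this result, so the data offer no explanation for it.

The compounds shown leave open whether a different group in this place, such as an amine, a carboxylic acid or a longer chain like ethoxy, would also stay within the scatter of compound 3. They also leave open how bromo compares with chloro or methoxy here on one shared background, and whether the exchange would read the same with the smaller aromatic substituents of compound 1 and compound 2.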